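This account rests on a few compounds, and the source may have more. Where it says the series, first, only, none or still open, it means among the compounds named here.

Working notes on the series, read-out a physicochemical assay for pharmacokinetics; on this read-out higher numbers stand for a longer-lived compound and lower numbers for a shorter-lived compound. Compound 2 (`O=C(NCc1ccccc1)N1C(=O)c2ccccc2S1(=O)=O`) gives > 166 h, which is a limit of the assay and not a number. Compound 1 (`O=C(NCc1cccc(Br)c1)N1C(=O)c2ccccc2S1(=O)=O`) gives > 166 h, again a limit. The measured compounds therefore share a single reading, (the limit of > 166 h in this assay, at which 2 of the 2 values shown sit), and compound 2 has no exact position on the scale.

Compound 3 (`O=C(NCC1CCCCC1)N1C(=O)c2ccccc2S1(=O)=O`) differs from compound 2 by cyclohexyl in place of phenyl on a saturated chain carbon bound to an amide-type nitrogen, or benzyl to cyclohexylmethyl when cut one bond further out. Among the measured compounds shown here, the only measured step, hydrogen in place of bromo on an aromatic carbon, is a step that the two limits leave unreadable from compound 1 to compound 2. It sits at a different place in the structure, and its size cannot be read, so it offers no magnitude to carry over.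

In this assay, no expected change beyond the usual scatter and no expected direction follow from these data, and the estimated step is a step that the limit leaves unreadable from compound 2 to compound 3. Another limit reading would not be surprising. For compound 3 the expected half-life is 200 h, with an estimated range of 100 h to 400 h.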

Compound 3, half-life: > 166 h
Compound 3: only a limit was reported; the forecaster's own chance of this, stated with the estimate: 70%; the middle value does not contradict the limit.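

In this assay compound 3 gives > 166 h, a limit of the assay and not a number. No new step can be read among compound 1, compound 2 and compound 3, because all three readings stand at one limit: the limit of > 166 h in this assay, at which 3 of the 3 values shown sit.

The compounds shown leave open the actual half-life of each compound and whether either structural change alters it.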